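The source may hold more compounds than are shown below. What is called first, only, known or untested is meant among the compounds shown, and "the series" means these compounds.

Measured so far:
Compound 1, `O=c1[nH]c(=O)n([C@H]2S[C@H](CO)[C@@H](O)[C@@H]2O)cc1I`. In a functional assay on CCRF-HSB-2 cells (Homo sapiens) for antiproliferative activity (on this read-out lower numbers stand for stronger inhibition and higher numbers for weaker inhibition), compound 1 gives > 100 ug/mL, which is a limit of the assay and not a number.
Compound 2, `Nc1nc(N)c2ncn([C@H]3C[C@H](O)[C@@H](CO)O3)c2n1`. In this assay compound 2 gives 1.7 ug/mL.
Compound 3, `O=c1[nH]c(=O)n([C@@H]2S[C@H](CO)[C@@H](O)[C@@H]2O)cc1I`. In this assay compound 3 gives > 100 ug/mL, again a limit of the assay rather than a number.

For the measured compounds named here, compound 1 therefore stands at the limit of this assay together with compound 3, while compound 2 is the only compound of the three with a readable number. The next compound is compound 4, `O=c1[nH]c(=O)n([C@H]2S[C@H](CO)[C@@H](O)[C@@H]2O)cc1/C=C/Cl`, which differs from compound 1 by 2-chloroethenyl in place of iodo on an aromatic carbon.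

Going by the values given here, only one step between measured compounds differing in one place is known, a step that the two limits leave unreadable from compound 1 to compound 3, and that step concerns configuration alone, as the fact that compounds 1 and 3 differ only in the configuration as drawn shows; it cannot be sized because the limit of > 100 ug/mL in this assay, at which 2 of the 3 values shown sit, hides both of its ends. Among the compounds with values here, no measured step replaces the iodo group by anything, so nothing in the numbers bears directly on the change from compound 1 to compound 4.

Without a comparable step, the working expectation is that compound 4 stays near where compound 1 stands, so that a number no higher from compound 1 to compound 4 (the limit leaves the size open) is expected to be small or again unreadable. Compound 4 is accordingly estimated at 100 ug/mL in this assay, within 20 ug/mL to 300 ug/mL.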

Compound 4, half-maximal inhibitory concentration: > 100 ug/mL
Compound 4: only a limit was reported; the forecaster's own chance of this, stated with the estimate: 65%; the middle value sits exactly at the limit.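

In this assay compound 4 gives > 100 ug/mL, a limit of the assay and not a number. For the compounds shown here, compound 1 also stands at a limit, so no step from compound 1 to compound 4 can be read. The compounds shown leave open whether any group in place of iodo on this aromatic carbon gives a readable number in this assay.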